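A few compounds are considered here, and "the series" means these few. Any claim that something is new, unique, unknown or untested is made for them only; others in the source may bear on it.

Compound 2, with the structure `COc1cc(OC)cc(-c2cn(-c3ccc(O)c(C(=O)OCCCc4ccccc4)c3)nn2)c1`, gives 19% in a functional assay on HCT-116 cells (Homo sapiens) for inhibition, read by MTT assay, with a stated time of 2 days, tested at 10 uM; a higher number here means more inhibition at the concentration tested (going by the name of the read-out), a lower number less inhibition. Of the two numbers recorded so far it is the higher, but its nearest neighbour, compound 1, with the structure `O=C(OCCCc1ccccc1)c1cc(-n2cc(-c3cccc(O)c3)nn2)ccc1O`, gives 11%, and the step of a number 8 percentage points higher from compound 1 to compound 2 (within the scatter) lies within the usual scatter, so the two compounds cannot be told apart on these numbers.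

Compound 3, with the structure `O=C(OCCCc1ccccc1)c1cc(-n2cc(-c3cc(O)ccc3O)nn2)ccc1O`, arises from compound 2 by the change (2,5-dihydroxyphenyl in place of 3,5-dimethoxyphenyl on an aromatic carbon).

Among the compounds with values here, the only measured step that bears on this change is the one from compound 1 to compound 2, where a 3-hydroxyphenyl was replaced by a 3,5-dimethoxyphenyl and the read-out moved by a number 8 percentage points higher from compound 1 to compound 2 (within the scatter), a shift within the scatter. Compound 3 goes back to a phenyl carrying hydroxyl groups, now two of them, and nothing measured here suggests that such a swap shifts the read-out beyond the scatter. The expected step is therefore a number 5 percentage points lower from compound 2 to compound 3 (within the scatter), in neither direction in particular. For compound 3 the estimate in this assay is 14%, with a range from 2% to 30%.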

Compound 3, a percentage reported as inhibition, at one concentration (the size of the read-out at that concentration, not a potency): 39%
Compound 3: middle estimate off by 25 percentage points, on the low side; the measured number lies above the stated range.
By their numbers in this assay, from the lowest: compounds 1 and 2 (each within the scatter of the next); then compound 3.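

In this assay, the aromatic group at this carbon of the five-membered ring with 3 nitrogen can make a measurable difference: 2,5-dihydroxyphenyl in place of 3,5-dimethoxyphenyl gives a number 20 percentage points higher from compound 2 to compound 3 (beyond the scatter). This swap removes two methoxy groups and brings in two hydroxy groups, and the entering group has 2 hydrogen-bond donors where the leaving group has 0, but the step alone cannot show which of these differences matters. The second comparison is narrower, since hydroxy in place of hydrogen on an aromatic carbon gives a number 28 percentage points higher from compound 1 to compound 3 (beyond the scatter), so compound 3 stands apart from both other compounds, whereas compound 1, which also carries a hydroxy group, shows only a number 8 percentage points higher from compound 1 to compound 2 (within the scatter) and cannot be told apart from compound 2, which goes against any simple rule that a hydroxy group on this ring is enough.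

Nothing available here explains why the second hydroxy group goes with the higher reading. Going by these compounds, it also remains open whether a hydroxy group is needed for this gain, or whether an amine or a carboxylic acid on the same ring would give a similar reading in this assay.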